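This account rests on a few compounds, and the source may have more. Where it says the series, first, only, none or still open, it means among the compounds named here.

Compound 1 `COc1cccc(-c2c(C)nn(-c3nc(-c4ccc(Cl)c(Cl)c4)c(SC(C)C)s3)c2C(=O)O)c1`; in a functional assay on BJAB cells (Homo sapiens) for antiproliferative activity, with a stated time of 4 days (a higher number here means that more compound is needed for the effect, a lower number that less compound is needed), compound 1 gives 14000 nM.
Compound 2 `Cc1nn(-c2nc(-c3ccc(Cl)c(Cl)c3)c(SC(C)C)s2)c(C(=O)O)c1Cc1ccccc1[N+](=O)[O-]`; in this assay compound 2 gives 20000 nM.
Compound 3 `Cc1nn(-c2nc(-c3ccc(Cl)c(Cl)c3)c(SC(C)C)s2)c(C(=O)O)c1-c1cc(C#N)cc(C(F)(F)F)c1`; in this assay compound 3 gives 3600 nM.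

Compound 3 stands at the lowest of the three numbers: a 3.9-fold lower number from compound 1 to compound 3 (0.59 log units; beyond the scatter) and a 5.6-fold lower number from compound 2 to compound 3 (0.74 log units; beyond the scatter), while a 1.4-fold higher number from compound 1 to compound 2 (0.15 log units; within the scatter). Compound 4 `Cc1nn(-c2nc(-c3ccc(Cl)c(Cl)c3)c(SC(C)C)s2)c(C(=O)O)c1-c1ccccc1Cl` differs from compound 3 in one place: 2-chlorophenyl in place of 3-cyano-5-(trifluoromethyl)phenyl on an aromatic carbon. The two steps that bear on this change, a 3.9-fold lower number from compound 1 to compound 3 (0.59 log units; beyond the scatter) and a 5.6-fold lower number from compound 2 to compound 3 (0.74 log units; beyond the scatter), both show that putting the 3-cyano-5-(trifluoromethyl)phenyl in lowered the number modestly; taking it out again for a plainer 2-chlorophenyl is therefore expected to raise the number by a modest amount in this assay, so that a 2.2-fold higher number from compound 3 to compound 4 (0.35 log units; beyond the scatter) is the expected step. Compound 4 is estimated at 8000 nM, within 3000 nM to 22000 nM.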

Compound 4, half-maximal effective concentration: 13100 nM
Compound 4: the middle estimate sits 1.6-fold (0.21 log units) below what was measured; the measured number falls inside the stated range.
By their numbers in this assay, from the lowest: compound 3; then compounds 4, 1 and 2 (each within the scatter of the next).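

In this assay, swapping the 3-cyano-5-(trifluoromethyl)phenyl for a 2-chlorophenyl takes away the advantage of compound 3 (a 3.6-fold higher number from compound 3 to compound 4 (0.56 log units; beyond the scatter)). The 2-chlorophenyl is not told apart from either the 2-nitrobenzyl (a 1.5-fold lower number from compound 2 to compound 4 (0.18 log units; within the scatter)) or the 3-methoxyphenyl (a 1.1-fold lower number from compound 1 to compound 4 (0.03 log units; within the scatter)), so among these four compounds only compound 3 stands apart at this aromatic carbon. Nothing available explains this difference. As far as these compounds go, whether an amine or a longer chain at this position would join compound 3 or the other three remains open.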